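Can an aromatic ring bring compound 3 back?

This account rests on a few compounds, and the source may have more. Where it says the series, first, only, none or still open, it means among the compounds named here.

In a functional assay on A-375 cells (Homo sapiens) for cytotoxicity, read by MTT assay (a higher number here means a weaker inhibitor, a lower number a stronger inhibitor), compound 3 (`COc1ccc(/C=C/C(=O)c2ccc(OC)c3c2OC(C)(C)C=C3)cc1CS(C)(=O)=O`) gives > 10000 nM as its result, and this is a limit of the assay, not a number. Compound 1 (`COc1ccc(/C=C/C(=O)c2ccc(OC)c3c2OC(C)(C)C=C3)cc1OC(=O)c1ccc(Br)cc1`) gives 420 nM in this assay as a true measurement. Compound 2 (`COc1ccc(/C=C/C(=O)Oc2cc(/C=C/C(=O)c3ccc(OC)c4c3OC(C)(C)C=C4)ccc2OC)cc1`) gives 2630 nM on the same scale.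

Compound 4 (`COc1ccc(/C=C/C(=O)c2ccc(OC)c3c2OC(C)(C)C=C3)cc1OS(=O)(=O)c1ccc(C)cc1`) alters compound 3 in one place, with ((4-methylphenyl)sulfonyl)oxy in place of (methylsulfonyl)methyl on an aromatic carbon ortho to a methoxy group (((4-methylphenyl)sulfonyl)oxy in place of (methylsulfonyl)methyl on an aromatic carbon). The entering group brings a six-membered aromatic ring of carbon only, as the ((4-bromophenyl)carbonyl)oxy group of compound 1 also does.

The closest guide is an at least 23-fold higher number from compound 1 to compound 3 (1.37 log units; beyond the scatter) when that group gives way to (methylsulfonyl)methyl. The other guide is a 6.3-fold higher number from compound 1 to compound 2 (0.80 log units; beyond the scatter) when 2-(4-methoxyphenyl)ethenyl replaces 4-bromophenyl on a carbonyl carbon, so changing the far end of this group also moved the number, by less. Going by the values given here, the sulfonyl link of compound 4 has no measured counterpart here.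

A large step toward a lower number is therefore expected in this assay, though the number is probably not expected to come down as far as that of compound 1, which gives 420 nM in this comparison. The expected change is an at least 6.6-fold lower number from compound 3 to compound 4 (0.82 log units; beyond the scatter) on this estimate. The estimate for compound 4 is 1500 nM with an expected range from 400 nM to 7000 nM as likely bounds.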

Compound 4, half-maximal inhibitory concentration: 2400 nM
The estimate for compound 4 lay 1.6-fold (0.20 log units) below the measured number, within the range that was stated.
By their numbers in this assay, from the lowest: compound 1; then compounds 4 and 2 (each within the scatter of the next). At a limit, above all of these: compound 3.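

Replacing (methylsulfonyl)methyl with ((4-methylphenyl)sulfonyl)oxy on this aromatic carbon gives an at least 4.1-fold lower number from compound 3 to compound 4 (0.61 log units; beyond the scatter), so a group carrying a six-membered aromatic ring of carbon only can return this position to a measurable result. Putting (4-methylphenyl)sulfonyl in place of (2-(4-methoxyphenyl)ethenyl)carbonyl on the oxygen gives a 1.1-fold lower number from compound 2 to compound 4 (0.04 log units; within the scatter), so these two quite different groups cannot be told apart here. Putting it in place of (4-bromophenyl)carbonyl on that same oxygen gives a 5.7-fold higher number from compound 1 to compound 4 (0.76 log units; beyond the scatter), which shows that an aromatic ring at this position does not by itself bring the number down to that of compound 1.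

Going by these compounds, the full size of the gain from compound 3 stays open, since compound 3 gives a limit of the assay and not a number: the limit of > 10000 nM in this assay, at which 1 of the 4 values shown sits. It is also unclear whether the gap to compound 1 comes from the sulfonyl link or from the bromine in place of the methyl group on the far ring, and whether an amine on that ring, or a simple hydroxyl group in place of the whole ester or sulfonate, would keep the activity.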